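From compound 1 to compound 3: adding dimethylamino

The compounds below may be only part of what the source reports. "The series", "measured", "known", "first", "only" and "open" are said of these compounds alone.

Measured in a functional assay on HCT-116 cells (Homo sapiens) for cytotoxicity, read by MTT assay; a higher number here means a weaker inhibitor, a lower number a stronger inhibitor:
Compound 1 `Cc1cc(O)c(C(=O)/C=C/c2ccccc2)c(=O)o1`: > 100000 nM
Compound 2 `Cc1cc(O)c(C(=O)/C=C/c2cccs2)c(=O)o1`: > 100000 nM

Both entries are limits of the test, not numbers. Compound 1 therefore has no exact value to start from, only its limit of > 100000 nM in this assay. The measurements so far amount to the limit of > 100000 nM in this assay, at which 2 of the 2 values shown sit.

Compound 3 `Cc1cc(O)c(C(=O)/C=C/c2ccc(N(C)C)cc2)c(=O)o1` keeps the core of compound 1 and differs in one place: dimethylamino in place of hydrogen on an aromatic carbon. This is dimethylamino in place of hydrogen on an aromatic carbon, para to a large group.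

Among the measured compounds shown here, only one measured step bears on this change, a step that the two limits leave unreadable from compound 1 to compound 2. It swaps phenyl for thiophen-2-yl rather than adding a group, and its size cannot be read, so it offers no guide to size or direction. With nothing pointing either way, no step beyond the scatter is expected, and the expected step is a number no higher from compound 1 to compound 3 (the limit leaves the size open). The estimated value for compound 3 is 100000 nM, with an expected range from 30000 nM to 200000 nM. Another limit rather than a number would be no surprise.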

Compound 3, half-maximal inhibitory concentration: > 100000 nM
Compound 3 was reported as a limit; the forecaster's own chance of this, stated with the estimate: 60%; the middle value lies on the limit itself.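

In this assay compound 3 gives > 100000 nM, which is a limit and not a number. Among the compounds shown here, compound 1 also stands only at a limit, and no step between compound 1 and compound 3 can be read. The results so far show one picture: the limit of > 100000 nM in this assay, at which 3 of the 3 values shown sit.

The compounds shown leave open what size of effect, if any, dimethylamino has in this assay.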